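The source may hold more compounds than are shown below. What is called first, only, known or untested is meant among the compounds shown, and "the series" means these compounds.

Measured in an assay on CHO cells for displacement of a labelled ligand from adenosine receptor A3 (Homo sapiens), read by scintillation counting, with a stated time of 120 min, tested at 10 uM; on this read-out higher numbers stand for more inhibition at the one concentration tested (going by the name of the read-out) and lower numbers for less inhibition:

compound 1, `Nc1scc(CN2CCN(c3cccc(Cl)c3Cl)CC2)c1C(=O)c1ccc(Cl)cc1`: 0%
compound 2, `COc1ccc(N2CCN(Cc3csc(N)c3C(=O)c3ccc(Cl)cc3)CC2)cc1`: 0%
compound 3, `Nc1scc(CN2CCN(c3ccc([N+](=O)[O-])cc3)CC2)c1C(=O)c1ccc(Cl)cc1`: 2%

Compound 1 sits level with compound 2 at the digits given, the two together being the lowest of the three numbers; the furthest is compound 3, reached by a number 2 percentage points higher from compound 1 to compound 3 (within the scatter), which stays within the scatter. Within the data shown here, the whole series so far lies at the floor of this assay.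

Compound 4, `Nc1scc(CN2CCN(C3CCCCCC3)CC2)c1C(=O)c1ccc(Cl)cc1`, has not yet been measured. Against compound 1 the change is cycloheptyl in place of 2,3-dichlorophenyl on an amine nitrogen in a ring.

The steps recorded so far all touch the same place, the group on the ring amine nitrogen: no change at the digits printed from compound 1 to compound 2 (within the scatter), a number 2 percentage points higher from compound 1 to compound 3 (within the scatter) and a number 2 percentage points higher from compound 2 to compound 3 (within the scatter). None of them moves the number beyond the scatter, whether a methoxy group, a nitro group or the two chlorine atoms sit on that aromatic ring. Among the measured compounds shown here, none of these steps, however, exchanges an aromatic ring for a non-aromatic one, so the move to cycloheptyl has no direct precedent here; the only guide is that every change at this position so far has left the read-out flat.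

The step to compound 4 is therefore expected to be a number 2 percentage points higher from compound 1 to compound 4 (within the scatter), nothing beyond the scatter. For compound 4 the estimate is 2%, with a range from -8% to 14%.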

Compound 4, a percentage reported as inhibition, at one concentration (the size of the read-out at that concentration, not a potency): 0%
Compound 4: the middle estimate sits 2 percentage points above what was measured; low and high end bracket the measured number.
By their numbers in this assay, from the lowest: compounds 1, 2, 4 and 3 (each within the scatter of the next).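

In this assay, the position on the ring amine nitrogen can now be read for a non-aromatic ring as well: the steps are no change at the digits printed from compound 1 to compound 4 (within the scatter), a number 2 percentage points lower from compound 3 to compound 4 (within the scatter) and no change at the digits printed from compound 2 to compound 4 (within the scatter). Among these four compounds, with none going against it, the read-out stays flat whether the nitrogen carries cycloheptyl, a seven-membered non-aromatic ring of carbon only, or one of the three substituted aromatic rings, so aromatic character at this place does not separate them at the one concentration tested. Nothing available accounts for why all four numbers stay at the floor of this assay.

Still open, on these data alone, is whether any other group at this place would lift the number off the floor, for example a longer alkyl chain, a benzyl group or a chain ending in a carboxylic acid. Also open, as far as these compounds go, is whether a change elsewhere on the shared core, such as an amide in place of the free amine, would move the read-out when the group on the ring amine nitrogen is held constant.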